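The compounds below may be only part of what the source reports. "The series", "measured", "known", "first", "only" and "open" are said of these compounds alone.

Measured compounds in an ADME assay on MT4 cells (Homo sapiens) for cytotoxicity, read by MTT assay, with a stated time of 4 days; on this read-out higher numbers stand for lower toxicity in this test and lower numbers for higher toxicity in this test:
- compound 1 `O=C1c2sccc2NS(=O)(=O)N1Cc1ccccc1` gives 374000 nM
- compound 2 `O=C1c2sccc2N(Cc2cccc(Cl)c2)S(=O)(=O)N1Cc1ccccc1` gives only a limit, > 298000 nM
- compound 3 `O=C1c2sccc2N(Cc2ccc(Cl)cc2)S(=O)(=O)N1Cc1ccccc1` gives 8200 nM

Compound 2 stands at the limit of this assay, one of the values that sit there (the limit of > 298000 nM in this assay, at which 1 of the 3 values shown sits); no number is read for it. Compound 4 `N#Cc1ccc(CN2c3ccsc3C(=O)N(Cc3ccccc3)S2(=O)=O)cc1` differs from compound 2 by 4-cyanophenyl in place of 3-chlorophenyl on a saturated chain carbon bound to a sulfonamide nitrogen in a ring.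

Within the data shown here, two measured steps bear on the change. From compound 2 to compound 3, the move of the chlorine on the benzyl ring gave an at least 36-fold lower number from compound 2 to compound 3 (1.56 log units; beyond the scatter). From compound 1 to compound 3 the 4-chlorobenzyl gave a 46-fold lower number from compound 1 to compound 3 (1.66 log units; beyond the scatter), while from compound 1 to compound 2 the 3-chlorobenzyl gave a step that the limit leaves unreadable from compound 1 to compound 2. Among the measured compounds shown here, compound 4 carries a 4-substituted benzyl, but a nitrile rather than a chlorine, and no measured step covers the nitrile itself.

For compound 4 a lower number than the limit of compound 2 is expected, of a size smaller than the drop to compound 3, with wide uncertainty: the step is estimated as an at least 4.9-fold lower number from compound 2 to compound 4 (0.69 log units; beyond the scatter). The estimate for compound 4 in this assay is 60000 nM, between 10000 nM and 300000 nM.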

Compound 4, half-maximal cytotoxic concentration: 8500 nM
Compound 4: the middle estimate sits 7.1-fold (0.85 log units) above what was measured; measured number outside the range, below it.
By their numbers in this assay, from the lowest: compounds 3 and 4 (each within the scatter of the next); then compound 1.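

In this assay the 4-cyanobenzyl on the sulfonamide nitrogen in a ring gives a 44-fold lower number from compound 1 to compound 4 (1.64 log units; beyond the scatter), and the change from 3-chlorobenzyl to 4-cyanobenzyl gives an at least 35-fold lower number from compound 2 to compound 4 (1.54 log units; beyond the scatter). Cyano in place of chloro on an aromatic carbon gives a 1.0-fold higher number from compound 3 to compound 4 (0.02 log units; within the scatter), within the scatter, so the large step is no longer tied to the 4-chlorobenzyl alone, while compound 2, with its 3-chlorobenzyl, goes against it. Compound 2 holds a limit and not a number: the limit of > 298000 nM in this assay, at which 1 of the 4 values shown sits.

The compounds shown leave open how a 3-cyanobenzyl would read, which would help separate the group from its place on the benzyl ring. They also leave open how a 4-aminobenzyl or a 4-carboxybenzyl would read at this nitrogen.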